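The source may report more compounds than this note shows. Statements on the series, on what has been measured and on what is new or still open speak of the compounds shown alone.

Compound 1, `Cc1ccc2[nH]c(=O)c(-c3nc4cc([N+](=O)[O-])ccc4[nH]3)cc2c1`: > 100000 nM
Compound 2, `COc1ccc2[nH]c(=O)c(-c3nc4cc(F)ccc4[nH]3)cc2c1`: > 100000 nM

In a functional assay on HepG2 cells (Homo sapiens) for cytotoxicity, read by MTT assay, with a stated time of 48 h (a higher number here means a weaker inhibitor, a lower number a stronger inhibitor), compound 2 gives > 100000 nM, which is a limit of the assay and not a number. Compound 1 stands at the same limit, as noted in the limit of > 100000 nM in this assay, at which 2 of the 2 values shown sit. Compound 3, `O=c1[nH]c2ccccc2cc1-c1nc2cc(F)ccc2[nH]1`, differs from compound 2 by hydrogen in place of methoxy on an aromatic carbon. No measured step of this kind is shown, so no change beyond the scatter in this assay is expected from it. Compound 3 is therefore estimated at 150000 nM, within 50000 nM to 500000 nM, an expected step that the limit leaves unreadable from compound 2 to compound 3, most likely again reported only as a limit.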

Compound 3, half-maximal inhibitory concentration: 15200 nM
For compound 3 the middle estimate is 9.9-fold (0.99 log units) above the measured one, and the stated range ends above it.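

In this assay, hydrogen in place of methoxy on this aromatic carbon gives an at least 6.5-fold lower number from compound 2 to compound 3 (0.81 log units; beyond the scatter). This shows that the group at this position of the shared core can move the read-out, which the two compounds at the limit could not show. The full size of the step stays unknown, since compound 2 has only a limit: the limit of > 100000 nM in this assay, at which 2 of the 3 values shown sit.

On these data alone, whether an amine, a chlorine atom or a longer alkoxy chain at this carbon would give a readable value remains open. So does the contribution of the fluorine of compound 3.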